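Aryl ether variation at the terminal phenoxy ring

The source may hold more compounds than are shown below. What is called first, only, known or untested is meant among the compounds shown, and "the series" means these compounds.

Measured compounds:
compound 1, `Cc1cccc(Oc2cccc(COc3ccccc3CCC(=O)OCCCOP(=O)(O)OC[C@H](N)C(=O)O)c2)c1`, 0.29
compound 2, `N[C@@H](COP(=O)(O)OCCCOC(=O)CCc1ccccc1OCc1cccc(Oc2ccc(Br)cc2)c1)C(=O)O`, 0.97

In an assay on cells for activation of probable G-protein coupled receptor 34 (Mus musculus), with a stated time of 1 h (a higher number here means a larger maximal response, a lower number a smaller maximal response), compound 2 gives 0.97, the higher of the two numbers in hand, and compound 1 gives 0.29. Within the data shown here, the single measured step, a number 0.68 higher from compound 1 to compound 2 (beyond the scatter), shows that exchanging the terminal aryl group on the ether oxygen can move the maximal response a long way.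

Compound 3, `CC(C)(C)c1ccc(Oc2cccc(COc3ccccc3CCC(=O)OCCCOP(=O)(O)OC[C@H](N)C(=O)O)c2)cc1`, has not yet been measured. Relative to compound 2 the change is tert-butyl in place of bromo on an aromatic carbon, so the 4-bromophenoxy becomes a 4-(tert-butyl)phenoxy. Among the measured compounds shown here, no measured pair carries a tert-butyl, and the one recorded step compares groups of a different kind and arrangement, so it bears on this change only in showing how sensitive the read-out is to this part of the structure. The expectation is therefore anchored on compound 2 with a broad margin: compound 3 is estimated at 0.8 (range 0.4 to 1.1), the estimated step being a number 0.17 lower from compound 2 to compound 3 (beyond the scatter).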

Compound 3, intrinsic activity: the largest response reached, as a fraction of the reference agonist's: 0.079
Beside the measured number, compound 3's estimate is 0.72 above it; the measured number lies below the stated range.
By their numbers in this assay, from the lowest: compound 3; then compound 1; then compound 2.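

In this assay the group on the terminal ring can decide the outcome even with its place held fixed: on the same aromatic carbon, tert-butyl (4 heavy atoms) in place of bromo (1 heavy atom) gives a number 0.89 lower from compound 2 to compound 3 (beyond the scatter) and takes the series from its top to its bottom. The earlier step changed both the group and its arrangement, so it could not show this. The comparison with the 3-methylphenyl ether, a number 0.21 lower from compound 1 to compound 3 (beyond the scatter), also shows that a 4-substituted terminal ring does not bring a high maximal response by itself, since compound 3 goes against any such reading and only compound 2 among the three reaches a high value. Nothing in hand bears on the reason for these differences.

Going by these compounds, whether the high response of compound 2 belongs to bromo alone stays open, and chloro, fluoro or methyl on the same carbon would help to settle it. On these data alone, it is also open how a methoxy, a trifluoromethyl or an ethyl group there would fall between the bromo and tert-butyl results.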